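Trading one aryl group for another on the shared core

A few compounds are considered here, and "the series" means these few. Any claim that something is new, unique, unknown or untested is made for them only; others in the source may bear on it.

Compound 1 `COc1cc(NC(=O)Nc2cc(Nc3cccc(C(C)(C)C)c3)ncn2)cc(OC)c1` gives 68% in a functional assay on PC-9 cells (Homo sapiens) for inhibition, read by MTT assay, with a stated time of 48 h, tested at 10 uM; a lower number here means less inhibition, a higher number more inhibition at the concentration tested (going by the name of the read-out).
Compound 2 `CC(C)(C)c1ccc(Nc2cc(NC(=O)Nc3c(Cl)cccc3Cl)ncn2)cc1` gives 41.5% in this assay.
Compound 3 `COc1ccc(Nc2cc(NC(=O)Nc3c(Cl)cccc3Cl)ncn2)cc1C` gives 80.1% in this assay.

Among these three numbers, compound 1 stands second highest. Its nearest neighbour is compound 3, whose number lies higher by a margin beyond the usual scatter; the furthest is compound 2, whose number lies lower by a margin well beyond it. The three measured compounds differ from one another in more than one place, so none of these gaps can be pinned on a single change.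

Compound 4 `COc1cc(NC(=O)Nc2cc(Nc3ccc(C)c(C)c3)ncn2)cc(OC)c1` is not yet measured. It differs from compound 1 in one place: 3,4-dimethylphenyl in place of 3-(tert-butyl)phenyl on a nitrogen on an aromatic ring. Within the data shown here, no measured pair isolates this swap, and the two compounds that lack the 3-(tert-butyl)phenyl group stand on opposite sides of compound 1, so the known numbers give no direction for it. The expectation is therefore a modest step in this assay, slightly downward or none beyond the scatter, written as a number 8 percentage points lower from compound 1 to compound 4 (within the scatter). Compound 4 is estimated at 60%, within a range from 40% to 80%.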

Compound 4, a percentage reported as inhibition, at one concentration (the size of the read-out at that concentration, not a potency): 66%
Compound 4: the middle estimate sits 6 percentage points below what was measured; measured number inside the range.
By their numbers in this assay, from the lowest: compound 2; then compounds 4 and 1 (each within the scatter of the next); then compound 3.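

In this assay, among these compounds, putting 3,4-dimethylphenyl in place of 3-(tert-butyl)phenyl on a nitrogen on an aromatic ring gives a number 2 percentage points lower from compound 1 to compound 4 (within the scatter), the first step here in which only one place differs, so no other change blurs the reading. At this position, a group of 10 heavy atoms and one of 8 heavy atoms, both made only of carbon and each holding one six-membered aromatic ring, cannot be told apart in this read-out at the single concentration tested. No measurement at hand offers an explanation for this outcome.

The compounds shown leave open whether this position stays as undemanding when its aromatic ring carries something quite different, such as an amine, a carboxylic acid or a longer chain. They also leave open whether the same swap would read the same way on the version of the core found in compound 2 and compound 3, and whether two compounds that match at one concentration would also match in potency.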